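Working notes: furan-2-yl in place of methyl on the shared core

The source may report more compounds than this note shows. Statements on the series, on what has been measured and on what is new or still open speak of the compounds shown alone.

Of the compounds shown here, three have been measured in a functional assay on DU-145 cells (Homo sapiens) for cytotoxicity, read by MTT assay, with a stated time of 72 h; on this read-out lower numbers stand for an effect already at smaller amounts and higher numbers for an effect only at larger amounts of compound. Compound 1 `COc1cccc(Nc2cc(-c3ccccc3)oc(=O)c2)c1` gives 0.66 uM in this assay. Compound 3 `Cc1ccc(Nc2cc(-c3ccccc3)oc(=O)c2)cc1` gives 0.073 uM in this assay. Compound 2 `COc1ccc(Nc2cc(C)oc(=O)c2)cc1` returns only > 30 uM in this assay, which is a limit of the assay and not a number. Compound 2 therefore stands at the top edge of the numbers shown, at the limit of > 30 uM in this assay, at which 1 of the 3 values shown sits, with no measured value of its own.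

Compound 4 `COc1ccc(Nc2cc(-c3ccco3)oc(=O)c2)cc1` has not yet been measured. It differs from compound 2 by furan-2-yl in place of methyl on an aromatic carbon. Going by the values given here, no step between measured compounds has been computed for this series. What the values show is that compound 1 and compound 3, each carrying a phenyl where compound 2 carries a methyl, both give concentrations for half-maximal effect well inside the measured range, while compound 2 with the methyl stays at the limit. On that basis a large step downward, beyond the usual scatter, is expected for the change to compound 4, estimated as an at least 20-fold lower number from compound 2 to compound 4 (1.30 log units; beyond the scatter). For compound 4 the expected value in this assay is estimated at 1.5 uM, with a range from 0.3 uM to 10 uM.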

Compound 4, concentration for half-maximal effect: 1.95 uM
Estimate against measurement, compound 4: 1.3-fold (0.11 log units) below; low and high end bracket the measured number.
By their numbers in this assay, from the lowest: compound 3; then compound 1; then compound 4. At a limit, above all of these: compound 2.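

In this assay, going by these compounds alone, furan-2-yl in place of methyl on the aromatic carbon next to the ring oxygen gives an at least 15-fold lower number from compound 2 to compound 4 (1.18 log units; beyond the scatter), the first step that can be read with only one place changed. With the rest of the structure held constant, the group at this position alone separates a compound at the limit from one with a measured number, something compound 1 and compound 3 could not show, as each differs from compound 2 in more than one place. Compound 2 holds a limit of the assay and not a number, so the step fixes only a lower bound on the size of this change: the limit of > 30 uM in this assay, at which 1 of the 4 values shown sits.

Open, as far as these compounds go, is how a phenyl, a thiophen-2-yl or a longer chain such as n-butyl would read at this position with the rest of compound 4 unchanged. The compounds shown therefore cannot tell whether the step follows the five-membered aromatic ring, its ring oxygen or simply a group larger than methyl.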